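A few compounds are considered here, and "the series" means these few. Any claim that something is new, unique, unknown or untested is made for them only; others in the source may bear on it.

In a functional assay on DA-3 cells for cytotoxicity against DA-3 cell line (Mus musculus), read by MTT assay (a lower number here means a stronger inhibitor, a higher number a weaker inhibitor), compound 1 `CC(=O)[C@@]1(C)C(=O)O[C@@H](OC(=O)C(C)(C)C)[C@H]1C` gives 1000 nM, and compound 2 `CC(=O)O[C@@H]1OC(=O)[C@@](C)(C(C)=O)[C@@H]1C` gives 9000 nM. Compound 2 thus stands with the higher of the two numbers, its gap to compound 1 lying beyond the usual scatter. Compound 3 `CC(=O)[C@]1(C)C(=O)O[C@@H](OC(=O)C(C)(C)C)[C@H]1C` has not yet been measured in this assay. Against compound 2 it carries the change (tert-butyl in place of methyl on a carbonyl carbon), tert-butyl in place of methyl on a carbonyl carbon. On the strength of compound 1 at 1000 nM, the step from compound 2 to compound 3 is expected to run downward, to a lower number beyond the scatter, as a 3.6-fold lower number from compound 2 to compound 3 (0.56 log units; beyond the scatter). Compound 3 is therefore estimated at 2500 nM, within a range from 600 nM to 10000 nM.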

Compound 3, half-maximal inhibitory concentration: 4000 nM
For compound 3 the middle estimate is 1.6-fold (0.20 log units) below the measured one; low and high end bracket the measured number.
By their numbers in this assay, from the lowest: compound 1; then compound 3; then compound 2.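

In this assay, tert-butyl in place of methyl on a carbonyl carbon gives a 2.3-fold lower number from compound 2 to compound 3 (0.35 log units; beyond the scatter) and so, with the configuration held as in compound 3, lowers the number by a modest step. Configuration matters at least as much here, as the other step is a 4.0-fold higher number from compound 1 to compound 3 (0.60 log units; beyond the scatter) and that comparison isolates a single stereocentre: the fact that compounds 1 and 3 differ only in the configuration as drawn.

The compounds shown leave open how a longer chain or a phenyl group would read on that carbonyl carbon. They also leave open whether the stereocentre would give a step of similar size with methyl there.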